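Shared-core amides: antiproliferative readings and one open estimate

This account rests on a few compounds, and the source may have more. Where it says the series, first, only, none or still open, it means among the compounds named here.

Compound 1 `CCOc1cc(NC(=O)CCCCC(=O)Nc2cc(-c3ccc(C)s3)ccc2N)cc2c1OCC([N+](=O)[O-])=C2`: 7910 nM.
Compound 2 `CCOc1cc(NC(=O)CCCCCNC(=O)CCCc2ccccc2)cc2c1OCC([N+](=O)[O-])=C2`: 5960 nM.
Compound 3 `CCOc1cc(NC(=O)CCCCCC(=O)Nc2cc(-c3ccc(C)s3)ccc2N)cc2c1OCC([N+](=O)[O-])=C2`: > 20000 nM, a limit of the assay rather than a number.

All three were read in a functional assay on MCF7 cells (Homo sapiens) for antiproliferative activity, read by MTT assay, with a stated time of 48 h; on this read-out lower numbers stand for stronger inhibition of growth and higher numbers for weaker inhibition of growth. Compound 1 has the highest of the two numbers; compound 2 sits close to it, and the gap between them lies within the scatter, so no order is drawn from it. For compound 3 only the limit of > 20000 nM in this assay, at which 1 of the 3 values shown sits, is recorded. Compound 4 `CCOc1cc(NC(=O)CCCCC(=O)Nc2ccccc2N)cc2c1OCC([N+](=O)[O-])=C2` is not yet measured; it differs from compound 1 by hydrogen in place of 5-methylthiophen-2-yl on an aromatic carbon. For the measured compounds named here, no step between measured compounds is at hand to size this change. The expectation for compound 4 in this assay is a modest rise in the number, as the step of a 1.5-fold higher number from compound 1 to compound 4 (0.18 log units; within the scatter), possibly no more than the scatter. Compound 4 is estimated at 12000 nM, within 4000 nM to 30000 nM.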

Compound 4, concentration for 50% growth inhibition: 17300 nM
Compound 4: the middle estimate sits 1.4-fold (0.16 log units) below what was measured; measured number inside the range.
By their numbers in this assay, from the lowest: compounds 2 and 1 (each within the scatter of the next); then compound 4. At a limit, above all of these: compound 3.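

Replacing 5-methylthiophen-2-yl with hydrogen on this aromatic carbon, para to an amino group, gives a 2.2-fold higher number from compound 1 to compound 4 (0.34 log units; beyond the scatter) in this assay, so this position does register in growth inhibition, though the step is modest. Compound 4 still gives a number rather than a limit, so a reading in this assay does not depend on the thiophene. The measurements shown give no account of why the number moves.

As far as these compounds go, whether a smaller group at this place, such as methyl or an unsubstituted thiophene, recovers the number of compound 1 stays open. So does the size of the same change on the longer chain of compound 3.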